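A few compounds are considered here, and "the series" means these few. Any claim that something is new, unique, unknown or untested is made for them only; others in the source may bear on it.

Working notes on the series in an assay on CHO cells with Alpha-2B adrenergic receptor (Homo sapiens) as the target; on this read-out higher numbers stand for larger maximal responses and lower numbers for smaller maximal responses. Three members of the shared core have been measured, each differing only in one group on the aromatic ring. Compound 1 `CCOc1ccccc1OC(C)C1=NCCN1` gives 0.5 in this assay. Compound 2 `C=C(C)c1ccccc1OC(C)C1=NCCN1` gives 0.4. Compound 3 `COc1ccccc1OC(C)C1=NCCN1` gives 0.5. Going by the values given here, compound 2 is the reference point here; the steps to its two neighbours, a number 0.10 lower from compound 1 to compound 2 (within the scatter) and a number 0.10 higher from compound 2 to compound 3 (within the scatter), both lie within the scatter, so no member of the trio separates from the others.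

Compound 4 `C=COc1ccccc1OC(C)C1=NCCN1` is the next member, reached from compound 2 by the change (vinyloxy in place of 1-methylethenyl on an aromatic carbon). The entering group sits on an aromatic carbon of a six-membered aromatic ring of carbon only, ortho to a group of 8 heavy atoms. Among the compounds with values here, two measured steps bear on this move, since each also exchanges the 1-methylethenyl for a group joined to the ring through oxygen: a number 0.10 higher from compound 2 to compound 3 (within the scatter) with methoxy, and, taken backwards, a number 0.10 lower from compound 1 to compound 2 (within the scatter) with ethoxy. Both stay inside the scatter. Vinyloxy is likewise joined through oxygen, so the step a number 0.10 higher from compound 2 to compound 4 (within the scatter) is expected to be of that same small kind, nominally upward but not beyond the scatter. Compound 4 is therefore estimated at 0.5, within 0.4 to 0.6.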

Compound 4, intrinsic activity: the largest response reached, as a fraction of the reference agonist's: 0.45
Compound 4: the middle estimate sits 0.050 above what was measured; the measured number falls inside the stated range.
By their numbers in this assay, from the lowest: compounds 2, 4, 1 and 3 (each within the scatter of the next).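

In this assay the change at this aromatic carbon, ortho to a group of 8 heavy atoms, gives a step of the small kind, a number 0.050 higher from compound 2 to compound 4 (within the scatter), even though vinyloxy brings one hydrogen-bond acceptor where 1-methylethenyl has none and the two groups carry the same count of 3 heavy atoms. Going by these compounds alone, compound 4 is also the first member with a double bond on the oxygen, and neither comparison with the saturated groups on that oxygen separates it: the steps are a number 0.050 lower from compound 3 to compound 4 (within the scatter) and a number 0.050 lower from compound 1 to compound 4 (within the scatter), so vinyl, methyl and ethyl on this oxygen cannot be told apart on this read-out. No supporting measurement is available to account for this close grouping of the four compounds.

The groups shown at this place are only methoxy, ethoxy, vinyloxy and 1-methylethenyl, so what an amine, a carboxylic acid or a longer chain such as butoxy would give remains open. On these data alone, the read-out also covers only the largest response reached, so how the four compounds compare in potency remains open as well.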